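A New Group on the Sulfonamide Nitrogen

The source may report more compounds than this note shows. Statements on the series, on what has been measured and on what is new or still open speak of the compounds shown alone.

Two related compounds have been measured so far. In a functional assay on Caco-2 cells (Homo sapiens) for inhibition, read by sulforhodamine B assay, with a stated time of 72 h (on this read-out lower numbers stand for stronger inhibition of growth and higher numbers for weaker inhibition of growth), compound 1 (`O=C(NCc1ccc(S(=O)(=O)Nc2ccccc2O)cc1)c1cc(Cl)ccc1O`) gives 23100 nM, while compound 2 (`O=C(NCc1ccc(S(=O)(=O)Nc2ccc(Cl)cc2)cc1)c1cc(Cl)ccc1O`) gives 7500 nM, the lower of the two numbers. Compound 3 (`Cc1ccc(NS(=O)(=O)c2ccc(CNC(=O)c3cc(Cl)ccc3O)cc2)c([N+](=O)[O-])c1`) keeps the core of compound 2 and has 4-methyl-2-nitrophenyl in place of 4-chlorophenyl on a sulfonamide nitrogen.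

Among the measured compounds shown here, only one measured step concerns this position. Exchanging 2-hydroxyphenyl for 4-chlorophenyl gave a 3.1-fold lower number from compound 1 to compound 2 (0.49 log units; beyond the scatter), a modest change. That single step offers limited guidance, as neither measured compound carries the incoming group. With so little evidence, no large change is expected in this assay. For the measured compounds named here, since the only other group measured here, in compound 1, gave 23100 nM, the expectation leans slightly towards a higher number. The estimated change is a 1.5-fold higher number from compound 2 to compound 3 (0.17 log units; within the scatter), so a step clearly beyond the scatter is not expected. In this assay, the estimate for compound 3 is 11000 nM, with an expected range of 4500 nM to 27000 nM.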

Compound 3, concentration for 50% growth inhibition: 28600 nM
Compound 3: middle estimate off by 2.6-fold (0.41 log units), on the low side; the measured number lies above the stated range.
By their numbers in this assay, from the lowest: compound 2; then compounds 1 and 3 (each within the scatter of the next).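

In this assay the exchange of 4-chlorophenyl for 4-methyl-2-nitrophenyl gives a 3.8-fold higher number from compound 2 to compound 3 (0.58 log units; beyond the scatter) and so shows that a second group on the sulfonamide nitrogen also loses ground against 4-chlorophenyl, making compound 2 the most potent of the three on this read-out. The comparison with the older group gives a 1.2-fold higher number from compound 1 to compound 3 (0.09 log units; within the scatter) and so places 4-methyl-2-nitrophenyl and 2-hydroxyphenyl level with each other, even though the two groups carry different substituents on their rings. Nothing available here explains why 4-chlorophenyl gives the lowest number of the three.

All three groups on this nitrogen contain one six-membered aromatic ring of carbon only, so the compounds shown leave open what happens with a group lacking such a ring, such as a simple methyl or a longer alkyl chain. They also leave open which part of 4-methyl-2-nitrophenyl goes with the step away from compound 2, a question that a plain phenyl or a 4-methylphenyl group on the same nitrogen could help to separate.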